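Chloro in Place of Fluoro: What to Expect for Compound 3

The compounds below may be only part of what the source reports. "The series", "measured", "known", "first", "only" and "open" are said of these compounds alone.

Of the compounds shown here, two have so far been tested in a functional assay on A-431 cells (Homo sapiens) for antiproliferative activity, read by MTT assay, with a stated time of 72 h; on this read-out higher numbers stand for weaker inhibition and lower numbers for stronger inhibition. Compound 1 `NS(=O)(=O)c1ccc(NC(=S)Nc2ccc3ncnc(Nc4ccc(Cl)c(C(F)(F)F)c4)c3c2)cc1` gives 18200 nM. Compound 2 `NS(=O)(=O)c1ccc(NC(=S)Nc2ccc3ncnc(Nc4cccc(F)c4)c3c2)cc1` gives 30100 nM, the higher of the two numbers, but the step of a 1.7-fold higher number from compound 1 to compound 2 (0.22 log units; within the scatter) lies within the scatter, so the two compounds cannot be told apart on this read-out. Compound 3 `NS(=O)(=O)c1ccc(NC(=S)Nc2ccc3ncnc(Nc4cccc(Cl)c4)c3c2)cc1` has not yet been measured. It differs from compound 2 by chloro in place of fluoro on an aromatic carbon, which read one bond further out is 3-fluorophenyl to 3-chlorophenyl. Going by the values given here, the one measured step that bears on this position, a 1.7-fold higher number from compound 1 to compound 2 (0.22 log units; within the scatter), exchanged the whole aryl group on that nitrogen and still stayed within the scatter, so a far smaller exchange of one halogen for another is expected to move the number by no more than the scatter, as in the estimated step of a 1.2-fold lower number from compound 2 to compound 3 (0.08 log units; within the scatter). Compound 3 is therefore expected to give about 25000 nM in this assay, with a range from 9000 nM to 70000 nM.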

Compound 3, half-maximal inhibitory concentration: 15000 nM
The estimate for compound 3 lay 1.7-fold (0.22 log units) above the measured number, and the stated range covers the measured number.
By their numbers in this assay, from the lowest: compounds 3, 1 and 2 (each within the scatter of the next).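

Exchanging fluoro for chloro on this phenyl ring leaves the number within the scatter in this assay (a 2.0-fold lower number from compound 2 to compound 3 (0.30 log units; within the scatter)), so the two halogens cannot be told apart at this position. Going by these compounds alone, exchanging the whole aryl group on that nitrogen gives the same kind of result (a 1.2-fold lower number from compound 1 to compound 3 (0.08 log units; within the scatter)), and all three aryl groups now lie within the scatter of one another, which the single earlier step could not show. No measurement is available to explain this flat result.

As far as these compounds go, all three compounds carry a halogen-bearing phenyl group on that nitrogen, so it remains open whether a group of another kind on this ring, such as an amine or a carboxylic acid, would move the number beyond the scatter. The rest of the molecule is the same in all three compounds, so they say nothing about changes there.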